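The compounds below may be only part of what the source reports. "The series", "measured", "known", "first", "only" and "open" are said of these compounds alone.

Three compounds have been measured in a functional assay on SW1573 cells (Homo sapiens) for antiproliferative activity, read by sulforhodamine B assay, with a stated time of 48 h; on this read-out lower numbers stand for stronger inhibition of growth and higher numbers for weaker inhibition of growth:

Compound 1 `CCCCCCC[C@H]1C[C@H](Cl)CCN1S(=O)(=O)c1ccc(C)cc1`: its value is a limit of the assay, > 100000 nM.
Compound 2 `Cc1ccc(S(=O)(=O)N2CC[C@@H](Cl)C[C@@H]2C2CCCCC2)cc1`: 53000 nM.
Compound 3 `CCCCCCCC1C=C(Br)CCN1S(=O)(=O)c1ccc(C)cc1`: 49000 nM.

Compound 1 stands at the limit of > 100000 nM in this assay, at which 1 of the 3 values shown sits, so the step to compound 2 is known only as a floor. That step, (cyclohexyl in place of heptyl on a saturated ring carbon), gives an at least 1.8-fold lower number from compound 1 to compound 2 (0.27 log units; that floor lies within the scatter). The values of compound 3 and compound 2 lie within the scatter of each other. The difference between the core of compound 3 and the core of compound 1 is not broken down here.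

Compound 4 `Cc1ccc(S(=O)(=O)N2CCC(Br)=CC2C2CCCCC2)cc1` has not been measured. It differs from compound 3 by cyclohexyl in place of heptyl on a saturated ring carbon. Going by the values given here, this is the same kind of change as the one from compound 1 to compound 2, but the place differs: there the ring atom two ring bonds away bears a chloro group, here it bears a bromo group. Because the step of an at least 1.8-fold lower number from compound 1 to compound 2 (0.27 log units; that floor lies within the scatter) is known only as a floor, for compound 4 a step of about that size or smaller is expected, a 1.6-fold lower number from compound 3 to compound 4 (0.21 log units; within the scatter). Compound 4 is therefore estimated at 30000 nM in this assay, between 10000 nM and 90000 nM.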

Compound 4, concentration for 50% growth inhibition: 65000 nM
The estimate for compound 4 lay 2.2-fold (0.34 log units) below the measured number, within the range that was stated.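

Cyclohexyl in place of heptyl, on a second core, gives a 1.3-fold higher number from compound 3 to compound 4 (0.12 log units; within the scatter) in this assay. Set beside the earlier case, the change offers only a loose comparison: the same change on two cores in this assay, an at least 1.8-fold lower number (0.27 log units; that floor lies within the scatter) from compound 1 to compound 2 and a 1.3-fold higher number (0.12 log units; within the scatter) from compound 3 to compound 4; the limit leaves it open whether they differ. On these data alone, compound 1 stands at a limit of the assay, > 100000 nM, so the true size of the first step stays unknown, and the pair shows neither that the change carries over from one core to the other nor that it behaves differently on the two.

The compounds shown leave open whether another group on this saturated ring carbon, such as a phenyl ring, a shorter chain or a chain ending in an amine, would move growth inhibition beyond the scatter. As far as these compounds go, it is also open whether a hydroxyl group or an amine in place of the chloro or bromo group would do so on either core.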